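Bromoacetyl in Place of Iodoacetyl on a Nucleoside Amide

The source may report more compounds than this note shows. Statements on the series, on what has been measured and on what is new or still open speak of the compounds shown alone.

Compound 1 `Cc1cn(C2CC(O)C(C(=O)Nc3ccc(C(=O)CI)cc3)O2)c(=O)[nH]c1=O`: 13 h
Compound 2 `Cc1cn(C2CC(O)C(CCC(=O)CCl)O2)c(=O)[nH]c1=O`: > 52 h
Compound 3 `Cc1cn(C2CC(O)C(CCC(=O)CBr)O2)c(=O)[nH]c1=O`: 1.8 h

In an ADME assay for pharmacokinetics (a higher number here means that the compound lasts longer, a lower number that the compound disappears faster), compound 1 holds the highest of the two numbers shown; the nearest number, that of compound 3, sits lower by a gap beyond the scatter. Compound 2 reaches (the limit of > 52 h in this assay, at which 1 of the 3 values shown sits), so its value is a limit and not a number.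

Compound 4 `Cc1cn(C2CC(O)C(C(=O)Nc3ccc(C(=O)CBr)cc3)O2)c(=O)[nH]c1=O` differs from compound 1 by bromo in place of iodo on a saturated chain carbon bound to a carbonyl carbon. For the measured compounds named here, the only measured halogen swap is an at least 28-fold lower number from compound 2 to compound 3 (1.46 log units; beyond the scatter), a large drop, but it concerns chloro against bromo, and no iodo-to-bromo step has been measured. That step therefore does not carry over directly, and for compound 4 a step of a 1.5-fold higher number from compound 1 to compound 4 (0.19 log units; within the scatter) is expected, within the scatter. Compound 4 is estimated at 20 h, between 5 h and 60 h.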

Compound 4, half-life: 4 h
For compound 4 the middle estimate is 5.0-fold (0.70 log units) above the measured one; the measured number lies below the stated range.
By their numbers in this assay, from the lowest: compound 3; then compound 4; then compound 1. At a limit, above all of these: compound 2.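

In this assay, the halogen on a saturated chain carbon bound to a carbonyl carbon also counts on the core of compound 1, where the change gives a 3.3-fold lower number from compound 1 to compound 4 (0.51 log units; beyond the scatter), a modest step. Together with an at least 28-fold lower number from compound 2 to compound 3 (1.46 log units; beyond the scatter), a large step on the other core, this leaves the bromo compound lower in both pairs. Nothing shown here accounts for either drop.

Open, on these data alone, is how a fluoro group or an amine on that carbon would read in this assay. Also open, as far as these compounds go, is whether iodo would stand above bromo on the core of compound 3 as well.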